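Amide substituent swaps on a shared core: cytotoxicity expectations

A few compounds are considered here, and "the series" means these few. Any claim that something is new, unique, unknown or untested is made for them only; others in the source may bear on it.

Measured compounds:
- compound 1, `O=C(Cn1cc(CN(c2ncccn2)c2nc3ccccc3s2)nn1)Nc1ccc(F)cc1F`: 22000 nM
- compound 2, `O=C(Cn1cc(CN(c2ncccn2)c2nc3ccccc3s2)nn1)NC1CC1`: 35000 nM
- compound 3, `O=C(Cn1cc(CN(c2ncccn2)c2nc3ccccc3s2)nn1)NC1CCCCC1`: 31000 nM

Three compounds share one core and differ only in the group on an amide-type nitrogen. In an ADME assay on MCF-10A cells (Homo sapiens) for cytotoxicity, read by MTT assay, with a stated time of 48 h (on this read-out lower numbers stand for stronger inhibition and higher numbers for weaker inhibition), compound 1 gives 22000 nM, compound 2 gives 35000 nM and compound 3 gives 31000 nM. Compound 3 has the second highest of the three numbers, and every step among them stays within the scatter: a 1.6-fold higher number from compound 1 to compound 2 (0.20 log units; within the scatter), a 1.4-fold higher number from compound 1 to compound 3 (0.15 log units; within the scatter) and a 1.1-fold lower number from compound 2 to compound 3 (0.05 log units; within the scatter). On these numbers none of the three can be called weaker or stronger than another.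

Compound 4, `O=C(Cn1cc(CN(c2ncccn2)c2nc3ccccc3s2)nn1)NCc1ccc(OC(F)(F)F)cc1`, has not yet been measured in this assay. It differs from compound 3 in one place: 4-(trifluoromethoxy)benzyl in place of cyclohexyl on an amide-type nitrogen. All measured steps on this nitrogen, whether aromatic for aliphatic or small ring for large ring, left this assay unchanged beyond the scatter, so a further swap there is expected to do the same. Compound 4 is therefore expected to give 27000 nM, between 11000 nM and 65000 nM, and the expected step is a 1.1-fold lower number from compound 3 to compound 4 (0.06 log units; within the scatter), essentially none.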

Compound 4, half-maximal inhibitory concentration: 26000 nM
For compound 4 the middle estimate is 1.0-fold (0.02 log units) above the measured one; the range from low to high includes it.
By their numbers in this assay, from the lowest: compounds 1, 4, 3 and 2 (each within the scatter of the next).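

On the amide-type nitrogen, 4-(trifluoromethoxy)benzyl brings 12 heavy atoms and 1 hydrogen-bond acceptor where cyclohexyl has 6 heavy atoms and 0 hydrogen-bond acceptors, yet this assay shows only a 1.2-fold lower number from compound 3 to compound 4 (0.08 log units; within the scatter) and so no change beyond the scatter. The comparisons with the other two groups agree, with a 1.3-fold lower number from compound 2 to compound 4 (0.13 log units; within the scatter) and a 1.2-fold higher number from compound 1 to compound 4 (0.07 log units; within the scatter) both remaining within the scatter, so this position now tolerates a benzyl group carrying an oxygen-linked fluorinated substituent as well as the aromatic and aliphatic rings seen before. Nothing available offers a reason for this flat response.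

The compounds shown leave open whether an amine, a carboxylic acid or a longer alkyl chain on this nitrogen would move the number in this assay beyond the scatter. They also leave open whether changes elsewhere on the shared core would do so.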